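The compounds below may be only part of what the source reports. "The series", "measured", "known", "first", "only" and "open" are said of these compounds alone.

Measured compounds:
Compound 1, `COc1cc(-n2ncnc2-c2ccc(Cl)cc2)cc(OC)c1OC`: in a functional assay on HL-60 cells (Homo sapiens) for antiproliferative activity, read by MTT assay, with a stated time of 72 h (a lower number here means a stronger inhibitor, a higher number a weaker inhibitor), compound 1 gives only a limit, > 10000 nM.
Compound 2, `COc1cc(-n2ncnc2-c2ccc(Cl)c(Cl)c2)cc(OC)c1OC`: in this assay compound 2 likewise gives only a limit, > 10000 nM.
Compound 3, `COc1cc(-c2ncnn2-c2ccc(Cl)cc2)cc(OC)c1OC`: in this assay compound 3 also gives only a limit, > 10000 nM.

Among the compounds with values here, all three values sit at the limit of > 10000 nM in this assay, at which 3 of the 3 values shown sit, so no step among the measured compounds can be read. The change from compound 2 to compound 1, (hydrogen in place of chloro on an aromatic carbon), gives a step that the two limits leave unreadable from compound 2 to compound 1. The cores of compound 2 and compound 3 are not the same, but the difference between the two cores is not broken down here.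

The unmeasured compound 4, `COc1cc(-c2ncnn2-c2ccccc2)cc(OC)c1OC`, arises from compound 3 by hydrogen in place of chloro on an aromatic carbon. This is the same kind of change as that from compound 2 to compound 1, though the place differs: there the leaving chloro stood ortho to a chloro group and meta to a large group, here it stands para to a large group. On these data alone, both members of the measured pair sit at the limit, so the size of that step is unknown.

Within the data shown here, the step from compound 3 to compound 4 is expected to be a step that the limit leaves unreadable from compound 3 to compound 4, because the limit of > 10000 nM in this assay, at which 3 of the 3 values shown sit, is where every value in this set sits and the one measured step of this kind gave no readable size. For compound 4 the expectation in this assay is 20000 nM, most likely again reported only as a limit, within 8000 nM to 60000 nM.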

Compound 4, half-maximal inhibitory concentration: > 10000 nM
Compound 4 gave a limit, no number; the forecaster's own chance of this, stated with the estimate: 85%; the middle value lies beyond the limit too.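

No new step can be read from compound 3 to compound 4, because both give only a limit and not a number: the limit of > 10000 nM in this assay, at which 4 of the 4 values shown sit.

The compounds shown leave open how far the 4-chlorophenyl to phenyl change, or the difference between the cores of compound 2 and compound 3, shifts the read-out in this assay and whether any compound on these cores gives a number there.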